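The source may report more compounds than this note shows. Statements on the series, on what has been measured and on what is new or still open speak of the compounds shown alone.

Measured compounds:
Compound 1 `C=C1CO[C@]2(CO[C@@H]3O[C@H](CO[C@@H]4OC[C@](O)(CO)[C@H]4O)[C@@H](O)[C@H](O)[C@H]3O)C(C)=CC[C@H]12`; in a functional assay on MNK45 cells (Homo sapiens) for cytotoxicity, read by MTT assay, with a stated time of 48 h (a lower number here means a stronger inhibitor, a higher number a weaker inhibitor), compound 1 gives 9400 nM.
Compound 2 `C[C@H]1[C@H]2C[C@H](O)[C@@](C)(O[C@@H]3O[C@H](CO)[C@@H](O)[C@H](O)[C@H]3O)[C@H]2CO[C@@H]1O`; in this assay compound 2 reaches only a limit of the assay, > 50000 nM, not a number.

Within the data shown here, compound 1 therefore stands alone as the one compound with a numerical reading in this assay; the only other value recorded is the limit of > 50000 nM in this assay, at which 1 of the 2 values shown sits, which shows nothing more than that compound 2 did not reach a measurable reading. Among the measured compounds shown here, no pair of measured compounds differing in a single place is available, so no measured step can be drawn on.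

The unmeasured compound 3 `C=C1CO[C@]2(CO[C@@H]3O[C@H](CO)[C@@H](O)[C@H](O)[C@H]3O)C(C)=CC[C@H]12` differs from compound 1 by hydrogen in place of 3,4-dihydroxy-4-(hydroxymethyl)oxolan-2-yl on an oxygen on a saturated carbon. With the shared core otherwise unchanged, the change is the loss of one outer sugar from the glycoside chain. Without a measured step of this kind, the expectation rests on compound 1 alone, and the step in this assay is expected to be small, at most a modest move toward a weaker inhibitor, possibly not beyond the scatter. Compound 3 is estimated to give 15000 nM, within a range from 5000 nM to 50000 nM, a step of a 1.6-fold higher number from compound 1 to compound 3 (0.20 log units; within the scatter).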

Compound 3, half-maximal inhibitory concentration: 8700 nM
Estimate against measurement, compound 3: 1.7-fold (0.24 log units) above; the measured number falls inside the stated range.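

Among these compounds, the measured pair gives the first reading of a single change at this position, which the earlier compounds could not supply. In this assay hydrogen in place of 3,4-dihydroxy-4-(hydroxymethyl)oxolan-2-yl on an oxygen on a saturated carbon gives a 1.1-fold lower number from compound 1 to compound 3 (0.03 log units; within the scatter) and so the two compounds read alike, which shows that the reading of compound 1 in this cell assay does not depend on this outer sugar. No measurement shown here offers a reason for this result.

Going by these compounds, whether this oxygen would read the same when carrying an amine-bearing sugar, a carboxylic acid or a longer chain of sugars remains open, as does the part played by the remaining sugar of compound 3, which stays in place in both compounds of the pair. Compound 2 differs from compound 1 and from compound 3 in more than one place, so the compounds shown do not tell which of its differences from them goes with its separate result.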